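Ethynyl in place of furan-3-yl: expected step for compound 4

A few compounds are considered here, and "the series" means these few. Any claim that something is new, unique, unknown or untested is made for them only; others in the source may bear on it.

In a functional assay on HepG2 cells (Homo sapiens) for antiproliferative activity, read by XTT assay, with a stated time of 72 h (a lower number here means a stronger inhibitor, a higher number a weaker inhibitor), compound 3 (`Cc1ncnc2c1c(-c1ccoc1)cn2[C@@H]1O[C@H](CO)[C@@H](O)[C@H]1O`) gives 5320 nM and holds the lowest of the two numbers in the series. Compound 1 (`C#Cc1cn([C@@H]2O[C@H](CO)[C@@H](O)[C@H]2O)c2ncnc(OC)c12`) stands nearest at 12700 nM in this assay and lies higher, beyond the scatter. Compound 2 (`C#Cc1cn([C@@H]2O[C@H](CO)[C@@H](O)[C@H]2O)c2ncnc(NC)c12`) gives > 15000 nM as a limit and not a number.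

Compound 4 (`C#Cc1cn([C@@H]2O[C@H](CO)[C@@H](O)[C@H]2O)c2ncnc(C)c12`) carries ethynyl in place of furan-3-yl on an aromatic carbon of compound 3, with this count: ethynyl in place of furan-3-yl on an aromatic carbon and no other difference between the two.

For the measured compounds named here, the only measured step is an at least 1.1-fold higher number from compound 1 to compound 2 (0.07 log units; that floor lies within the scatter) and it exchanges methoxy for methylamino, not furan-3-yl, so it gives no size for this change. Going by the values given here, no measured step covers the exchange of furan-3-yl, so no step beyond the scatter is expected in this assay here.

The expected step is a 1.2-fold higher number from compound 3 to compound 4 (0.09 log units; within the scatter) and it carries wide uncertainty. For compound 4 the estimated value is 6500 nM in this assay, with an expected range from 2000 nM to 15000 nM for this estimate.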

Compound 4, half-maximal inhibitory concentration: 290 nM
Beside the measured number, compound 4's estimate is 22-fold (1.35 log units) above it; the measured number lies below the stated range.
By their numbers in this assay, from the lowest: compound 4; then compound 3; then compound 1. At a limit, above all of these: compound 2.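

In this assay, the aromatic carbon two ring bonds from the ring nitrogen proves highly sensitive to its group: ethynyl in place of furan-3-yl gives an 18-fold lower number from compound 3 to compound 4 (1.26 log units; beyond the scatter). With ethynyl held fixed, the other substituted aromatic carbon also matters, a point compounds 1 and 2 could not establish on their own: methyl in place of methoxy gives a 44-fold lower number from compound 1 to compound 4 (1.64 log units; beyond the scatter). Methyl in place of methylamino gives an at least 51-fold lower number from compound 2 to compound 4 (1.71 log units; beyond the scatter), a floor only, as compound 2 carries a limit and not a number: the limit of > 15000 nM in this assay, at which 1 of the 4 values shown sits.

On these data alone, whether a nitrile or a propyl chain on the first carbon would keep compound 4's level, and so whether the triple bond itself matters, remains open. Also open, as far as these compounds go, is whether ethyl or chlorine could replace methyl on the second carbon without loss.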